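Swapping the Pyridyl Amide Group for a Hydroxyphenyl

This account rests on a few compounds, and the source may have more. Where it says the series, first, only, none or still open, it means among the compounds named here.

The compounds measured so far, each in an ADME assay on cells (Homo sapiens) for antiproliferative activity, read by MTT assay; a higher number here means a weaker inhibitor, a lower number a stronger inhibitor:

Compound 1, `C/C(=N\NC(=O)c1ccncc1)c1cnccn1`, gives 5790 nM.
Compound 2, `O=C(NN=C(c1ccccn1)c1ccccn1)c1ccc(C(F)(F)F)cc1`, gives 240 nM.
Compound 3, `O=C(NN=C(c1ccccn1)c1ccccn1)c1ccncc1`, gives 830 nM.

Compound 3 stands second highest of the three numbers. Its nearest neighbour is compound 2, whose lower number lies beyond the scatter, and its furthest is compound 1, whose higher number also lies beyond the scatter. Compounds 2 and 3 share the same core and differ only in the ring attached to the carbonyl carbon, which in compound 2 carries a trifluoromethyl group and in compound 3 is pyridin-4-yl.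

The next compound, compound 4, `O=C(NN=C(c1ccccn1)c1ccccn1)c1ccc(O)cc1`, keeps that shared core and alters only the ring on the carbonyl carbon. The change is 4-hydroxyphenyl in place of pyridin-4-yl on a carbonyl carbon.

Going by the values given here, no measured pair shows this exact swap, so the expected size of the step rests on a single comparison. A carbon-only ring on the carbonyl carbon gave a lower number in compound 2, which gives 240 nM, but a hydroxy group is not a trifluoromethyl group, so the step is expected to be modest, tending toward a lower number. The expected step from compound 3 to compound 4 is a 1.4-fold lower number from compound 3 to compound 4 (0.14 log units; within the scatter). Compound 4 is therefore estimated to give 600 nM, with a range from 200 nM to 1800 nM.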

Compound 4, half-maximal inhibitory concentration: 7530 nM
Compound 4: the middle estimate sits 13-fold (1.10 log units) below what was measured; measured number above the stated range.
By their numbers in this assay, from the lowest: compound 2; then compound 3; then compounds 1 and 4 (each within the scatter of the next).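

In this assay, putting 4-hydroxyphenyl in place of pyridin-4-yl on the carbonyl carbon gives a 9.1-fold higher number from compound 3 to compound 4 (0.96 log units; beyond the scatter), so a change at this one place on the shared core can move the number well beyond the scatter. The comparison with the other carbon-only ring is sharper still: hydroxy in place of trifluoromethyl on an aromatic carbon gives a 31-fold higher number from compound 2 to compound 4 (1.50 log units; beyond the scatter), and here the ring itself stays the same and only the group it carries differs. Across compounds 2, 3 and 4, then, a carbon-only ring on the carbonyl carbon does not by itself bring a lower number, since compound 2 sits lowest and compound 4 highest, with the pyridin-4-yl of compound 3 in between.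

Nothing available here explains why the hydroxy group goes with so much higher a number than the trifluoromethyl group.

These three compounds also leave open how the number would respond to other groups on that ring, such as a methoxy group, an amine or a carboxylic acid, and whether a plain phenyl ring would sit nearer compound 2 or compound 4.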